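The compounds below may be only part of what the source reports. "The series", "measured", "known", "first", "only" and "open" are said of these compounds alone.

Compound 2, with structure `CC(C)C[C@H](N)c1cc(C(F)(F)F)ccc1N1CCN(C(=O)COc2cccc(Cl)c2Cl)CC1`, gives 2500 nM in an assay on HEK293 cells for displacement of a labelled ligand from Melanocortin receptor 4 (Homo sapiens) (on this read-out higher numbers stand for weaker inhibition and lower numbers for stronger inhibition), the highest number among the three measured compounds and so the weakest inhibitor of the set. The two other measured compounds, compound 1 with structure `Cc1ccc(N2CCN(C(=O)[C@H](C)Cc3ccc(Cl)cc3F)CC2)c([C@@H](N)CC(C)C)c1` and compound 3 with structure `CC(C)C[C@H](N)c1ccccc1N1CCN(C(=O)[C@H](C)Cc2ccc(Cl)cc2Cl)CC1`, each carry a different acyl group on the shared core: in this assay compound 1 gives 20 nM and compound 3 gives 16 nM, both gaps to compound 2 lying beyond the usual scatter. No single-point comparison among these three compounds is available, so the values alone show that the arrangement of compound 2 is the weakest of the three.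

Compound 4, with structure `Cc1ccc(OCC(=O)N2CCN(c3ccc(C(F)(F)F)cc3[C@@H](N)CC(C)C)CC2)c(C)c1`, is not yet measured. It differs from compound 2 as follows: 2,4-dimethylphenyl in place of 2,3-dichlorophenyl on an oxygen on a saturated carbon

Going by the values given here, no measured pair shows the effect of this exchange, and the step is therefore expected to stay within the scatter, with no direction to be called. On that basis the value estimated for compound 4 in this assay is 2200 nM (range 600 nM to 8000 nM), which is expected to mean a step of a 1.1-fold lower number from compound 2 to compound 4 (0.06 log units; within the scatter).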

Compound 4, inhibition constant: 4000 nM
Compound 4: the middle estimate sits 1.8-fold (0.26 log units) below what was measured; measured number inside the range.
By their numbers in this assay, from the lowest: compounds 3 and 1 (each within the scatter of the next); then compounds 2 and 4 (each within the scatter of the next).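

In this assay, the exchange of 2,3-dichlorophenyl for 2,4-dimethylphenyl on an oxygen on a saturated carbon gives a 1.6-fold higher number from compound 2 to compound 4 (0.20 log units; within the scatter), so the two compounds cannot be told apart. Going by these compounds alone, this is the first pair in the set that differs in one place, and it shows that this position accepts a swap of the two chlorine atoms for carbon at equal heavy-atom count without a change beyond the scatter. Nothing at hand explains why the two groups read alike.

Going by these compounds, it remains open whether an unsubstituted phenyl or a pyridine on that oxygen would read the same, or whether an amine or a carboxylic acid on the ring would shift the number. Whether this single pair holds for other aryl groups also stays unsettled.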